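Swapping dimethylamino for cyclopropylamino on the shared core

A few compounds are considered here, and "the series" means these few. Any claim that something is new, unique, unknown or untested is made for them only; others in the source may bear on it.

In a toxicity assay on HepG2 cells (Homo sapiens) for inhibition, read by resazurin assay, with a stated time of 24 h (a lower number here means that less compound is tolerated, a higher number that more compound is tolerated), compound 1 (`CN(C)C(=O)c1ncc([N+](=O)[O-])n1C`) gives > 100000 nM as a limit of the assay. Compound 2 (`CN(C)C(=O)c1ncc([N+](=O)[O-])[nH]1`) gives > 100000 nM as a limit too. Compound 3 (`O=C(NC1CC1)c1ncc([N+](=O)[O-])[nH]1`) carries cyclopropylamino in place of dimethylamino on a carbonyl carbon. Within the data shown here, the one measured step is a step that the two limits leave unreadable from compound 1 to compound 2 and it sits at another place, so it gives no size to carry over. Both measured compounds share the limit of > 100000 nM in this assay, at which 2 of the 2 values shown sit, as their result. No change beyond the scatter is expected, so the estimate is a number no higher from compound 2 to compound 3 (the limit leaves the size open) in this assay for this swap. The estimate for compound 3 is 100000 nM with 50000 nM to 200000 nM as the expected range.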

Compound 3, half-maximal cytotoxic concentration: > 100000 nM
Compound 3 was reported as a limit; the forecaster's own chance of this, stated with the estimate: 80%; the middle value sits exactly at the limit.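

Among these compounds, compound 2 and compound 3 both return only a limit of the assay, so no step between them can be read. In this assay the compounds shown leave open at what concentration compound 1, compound 2 or compound 3 would become toxic, and whether the cyclopropylamino swap changes that concentration.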